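Acyl Group Variation at the Ring Nitrogen of Compound 3

The source may hold more compounds than are shown below. What is called first, only, known or untested is meant among the compounds shown, and "the series" means these compounds.

Measured compounds:
- compound 1 `COc1cc2nc(N3CCN(C(C)=O)[C@H]4CCCC[C@H]43)nc(N)c2cc1OC`: 105 nM
- compound 2 `CCCN(CCC)c1nc(N2CCN(C(=O)c3ccco3)[C@@H]3CCCC[C@@H]32)nc2cc(OC)c(OC)cc12`: 0.0631 nM
- compound 3 `COc1cc2nc(N3CCN(C(=O)C(C)(C)C)[C@H]4CCCC[C@H]43)nc(N)c2cc1OC`: 6.17 nM

In an assay on CHO cells for displacement of a labelled ligand from Alpha-1D adrenergic receptor (Homo sapiens), with a stated time of 30 min (on this read-out lower numbers stand for stronger inhibition and higher numbers for weaker inhibition), compound 1 gives 105 nM, compound 3 gives 6.17 nM and compound 2 gives 0.0631 nM. Compound 3 therefore stands second highest of the three numbers: its nearest neighbour is compound 1, and compound 2, which also carries a different group on the shared core, lies furthest from it with the lowest number of the set.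

Compound 4 `COc1cc2nc(N3CCN(C(=O)OCc4ccccc4)[C@H]4CCCC[C@H]43)nc(N)c2cc1OC` has not yet been measured. It differs from compound 3 in one place: benzyloxy in place of tert-butyl on a carbonyl carbon. Going by the values given here, the only measured step that bears on this change is a 17-fold lower number from compound 1 to compound 3 (1.23 log units; beyond the scatter), where a group with more heavy atoms entered on the same carbonyl carbon. Compound 4 again replaces the group on that carbon with one of more heavy atoms, now carrying a six-membered aromatic ring and one hydrogen-bond acceptor. Among the compounds with values here, a further drop in this assay is therefore expected, though smaller than the measured step, because only one step of a 17-fold lower number from compound 1 to compound 3 (1.23 log units; beyond the scatter) supports the direction and none shows the effect of an aromatic ring at this place.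

For compound 4 the expected value in this assay is 2 nM, within 0.4 nM to 10 nM, an expected step of a 3.1-fold lower number from compound 3 to compound 4 (0.49 log units; beyond the scatter).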

Compound 4, inhibition constant: 3.98 nM
Compound 4: the middle estimate sits 2.0-fold (0.30 log units) below what was measured; measured number inside the range.
By their numbers in this assay, from the lowest: compound 2; then compounds 4 and 3 (each within the scatter of the next); then compound 1.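

In this assay, benzyloxy in place of tert-butyl on the carbonyl carbon gives a 1.6-fold lower number from compound 3 to compound 4 (0.19 log units; within the scatter) and so the two groups cannot be told apart on this read-out, even though benzyloxy brings more heavy atoms, a six-membered aromatic ring and a hydrogen-bond acceptor. Against methyl, benzyloxy gives a 26-fold lower number from compound 1 to compound 4 (1.42 log units; beyond the scatter) and tert-butyl gives a 17-fold lower number from compound 1 to compound 3 (1.23 log units; beyond the scatter) so two quite different groups both stand clearly apart from methyl at this place, while the extra size of benzyloxy adds nothing that can be read beyond tert-butyl. No measurement shown explains why these groups give these numbers.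

Still open, on these data alone, is whether a chain ending in an amine or a carboxylic acid on the same carbonyl carbon would give a number close to those of compound 3 and compound 4. Also open, as far as these compounds go, is what the oxygen and the aromatic ring of benzyloxy each contribute, which a benzyl group without that oxygen or a cyclohexylmethoxy group with a saturated ring could separate.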